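Expectation for the next compound

The compounds below may be only part of what the source reports. "The series", "measured", "known", "first", "only" and "open" are said of these compounds alone.

In a functional assay on A549 cells (Homo sapiens) for cytotoxicity, read by MTT assay, with a stated time of 72 h (a higher number here means a weaker inhibitor, a lower number a stronger inhibitor), compound 1 (`COc1ncc(-c2ccc3nc(NC(=O)NC4CC4)nn3c2)cc1NS(=O)(=O)c1ccc(F)cc1`) gives 210 nM. Compound 2 (`CCCNC(=O)Nc1nc2ccc(-c3cnc(OC)c(NS(=O)(=O)c4ccc(F)cc4)c3)cn2n1`) gives 220 nM, which places it level with compound 1 within the scatter, so these two share the low end of the three numbers. Compound 3 (`CCN(CC)CCNC(=O)Nc1nc2ccc(-c3cnc(OC)c(NS(=O)(=O)c4ccc(F)cc4F)c3)cn2n1`) reads clearly higher at 980 nM, but it differs from compound 1 in more than one place, so its value isolates no single change and does not bear on the question here.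

The next compound is compound 4 (`CNC(=O)Nc1nc2ccc(-c3cnc(OC)c(NS(=O)(=O)c4ccc(F)cc4)c3)cn2n1`), which carries methyl in place of cyclopropyl on an amide-type nitrogen. For the measured compounds named here, only one measured step touches this nitrogen alone: a 1.0-fold higher number from compound 1 to compound 2 (0.02 log units; within the scatter), with propyl in place of cyclopropyl, and it lies within the scatter. That single step is thin support, since no group as small as methyl has yet been measured at this place. Even so, no shift beyond the scatter is expected, with a slight drift to a higher number as the only allowance. The expected move is a 1.2-fold higher number from compound 1 to compound 4 (0.08 log units; within the scatter). For compound 4 the estimated value is 250 nM, with an expected range of 110 nM to 550 nM.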

Compound 4, half-maximal inhibitory concentration: 230 nM
The estimate for compound 4 lay 1.1-fold (0.04 log units) above the measured number, within the range that was stated.
By their numbers in this assay, from the lowest: compounds 1, 2 and 4 (each within the scatter of the next); then compound 3.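

In this assay the group on the amide-type nitrogen now runs from methyl through propyl to cyclopropyl, and the numbers stay level across all of them (a 1.1-fold higher number from compound 1 to compound 4 (0.04 log units; within the scatter); a 1.0-fold higher number from compound 2 to compound 4 (0.02 log units; within the scatter)). Until now only the propyl for cyclopropyl step spoke for this nitrogen, and it left open whether a group of 1 heavy atom and no ring would hold the same level; among compounds 1, 2 and 4, neither the three-membered ring nor the extra chain carbons of propyl separates the numbers. No measurement in hand explains why this nitrogen shows so little response to the change.

Still open, going by these compounds, is whether this flat reading extends beyond small carbon-only groups, for instance to a phenyl ring, a hydroxyethyl chain or a carboxylic acid on the same nitrogen. Compound 3 differs from compound 1 in more than one place, so it leaves unsettled what a longer chain carrying an amine does here on its own.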